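Swapping a Thiazole for a Methylimidazole: a Solubility Expectation

The compounds below may be only part of what the source reports. "The series", "measured", "known", "first", "only" and "open" are said of these compounds alone.

Measured compounds:
compound 1, `CC(C)Cc1ncc2c(N)c(C#N)c(N)nc2n1`: 268000 nM
compound 2, `CC(C)(C)c1nc(-c2nccs2)c2c(N)c(C#N)c(N)nc2n1`: < 1500 nM

In a physicochemical assay for solubility, in phosphate buffer, with a stated time of 18 h (on this read-out higher numbers stand for higher solubility and lower numbers for lower solubility), compound 1 gives 268000 nM. For compound 2 the assay gives only a limit, < 1500 nM, and not a measured number. the limit of < 1500 nM in this assay, at which 1 of the 2 values shown sits, is therefore the place where compound 2 stands. Among the measured compounds shown here, no step between two measured compounds that differ in a single place is available, so the size of any change must be judged from the structures alone.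

Compound 3, `Cc1c[nH]c(-c2nc(C(C)(C)C)nc3nc(N)c(C#N)c(N)c23)n1`, differs from compound 2 in one place: 4-methyl-1H-imidazol-2-yl in place of 1,3-thiazol-2-yl on an aromatic carbon. The expected step from compound 2 to compound 3 in this assay is an at least 2.0-fold higher number from compound 2 to compound 3 (0.30 log units; that floor lies within the scatter), an upward move that may go beyond the scatter, although a limit reading for compound 3 remains possible. Compound 3 is estimated at 3000 nM, in a range from 1000 nM to 15000 nM.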

Compound 3, solubility: 5000 nM
Compound 3: middle estimate off by 1.7-fold (0.22 log units), on the low side; the range from low to high includes it.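

In this assay, putting 4-methyl-1H-imidazol-2-yl in place of 1,3-thiazol-2-yl on this aromatic carbon gives an at least 3.3-fold higher number from compound 2 to compound 3 (0.52 log units; beyond the scatter). Among the compounds shown here, this is the first comparison here between compounds that differ in one place, and it shows that the read-out responds to exchanging one five-membered aromatic ring for another at this position of the shared core. Compound 2 is read only as a limit, so the printed step is a floor and its full size stays unknown: the limit of < 1500 nM in this assay, at which 1 of the 3 values shown sits.

This single step cannot separate the added methyl group from the change of ring atoms, including the hydrogen-bond donor that the entering ring carries. Going by these compounds, how a simple amine or a carboxylic acid at this position would read in this assay also remains open.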